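This account rests on a few compounds, and the source may have more. Where it says the series, first, only, none or still open, it means among the compounds named here.

Compound 1 `O=C(CSc1nc(Nc2ccccc2)c2ccccc2n1)Nc1ccccc1F` — in a functional assay on MDA-MB-231 cells (Homo sapiens) for inhibition, read by MTT assay, with a stated time of 72 h (on this read-out lower numbers stand for stronger inhibition and higher numbers for weaker inhibition), compound 1 gives > 50000 nM, which is a limit of the assay and not a number.
Compound 2 `O=C(CSc1nc(Nc2ccccc2)c2ccccc2n1)Nc1ccc(C(F)(F)F)cc1` — compound 2 gives 11100 nM.
Compound 3 `C=CC(=O)Nc1cccc(NC(=O)CSc2nc(Nc3ccccc3C)c3ccccc3n2)c1` — compound 3 gives 20400 nM.

All three share one core and differ only in the groups attached to it. Of the two plain numbers shown, compound 3 stands at the top, but its gap to compound 2 lies within the usual scatter of this assay, so the two cannot be told apart. For the measured compounds named here, the single measured step, an at least 4.5-fold lower number from compound 1 to compound 2 (0.65 log units; beyond the scatter), exchanged the group on the amide-type nitrogen. Compound 4 `C=CC(=O)Nc1cccc(NC(=O)CSc2nc(Nc3cccc([N+](=O)[O-])c3)c3ccccc3n2)c1` changes a different part of the molecule: 3-nitrophenyl in place of 2-methylphenyl on a nitrogen on an aromatic ring. Going by the values given here, no measured step touches that nitrogen, so the one step known does not bear directly on this change, and the numbers give no reason to expect a shift beyond the scatter; the expected step is a 1.0-fold lower number from compound 3 to compound 4 (0.01 log units; within the scatter). Compound 4 is therefore estimated at 20000 nM, with a likely range from 6000 nM to 60000 nM.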

Compound 4, half-maximal inhibitory concentration: > 50000 nM
Compound 4 ended at the assay's limit; the forecaster's own chance of this, stated with the estimate: 25%; middle value at least 2.5-fold (0.39 log units) away from the limit.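

The nitrogen on an aromatic ring turns out to be a place where a change can be read: 3-nitrophenyl in place of 2-methylphenyl there gives an at least 2.4-fold higher number from compound 3 to compound 4 (0.38 log units; beyond the scatter) in this assay. For the compounds shown here, the group on this nitrogen therefore counts too, whereas the only earlier measured step concerned the amide-type nitrogen. Compound 4 gives > 50000 nM, which is a limit and not a number, so the full size of the step stays unknown, and this limit recurs in the set: the limit of > 50000 nM in this assay, at which 2 of the 4 values shown sit.

The compounds shown leave open whether the step follows from losing the methyl group or from gaining the nitro group, as both changes come together here. Going by these compounds, how a phenyl ring carrying an amine or a carboxylic acid on this nitrogen would read in this assay also remains open.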